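The compounds below may be only part of what the source reports. "The series", "measured", "known", "first", "only" and "open" are said of these compounds alone.

In a functional assay on A2780 cells (Homo sapiens) for antiproliferative activity, read by sulforhodamine B assay, with a stated time of 72 h (a higher number here means a weaker inhibitor, a lower number a stronger inhibitor), compound 1 (`Cc1cncc(CNC(=O)Nc2ccc(S(=O)(=O)N3CCOCC3)cc2)c1`) gives 1100 nM and compound 2 (`C[C@@H]1COC[C@@H](C)N1S(=O)(=O)c1ccc(NC(=O)NCc2cccnc2)cc1`) gives 745 nM. These two numbers lie within the usual scatter of each other, so compound 2 stands level with compound 1 on the data so far. Compound 3 (`CC1CNCCN(S(=O)(=O)c2ccc(NC(=O)NCc3cccnc3)cc2)C1`) has yet to be measured. It departs from compound 2 on a sulfonyl sulfur: a group of 8 heavy atoms (6 carbon, 2 nitrogen; one seven-membered non-aromatic ring with 2 hetero atoms) in place of a group of 8 heavy atoms (6 carbon, 1 nitrogen, 1 oxygen; one six-membered non-aromatic ring with 2 hetero atoms), on a sulfonyl sulfur. The 3,5-dimethylmorpholin-4-yl group leaves, and a seven-membered non-aromatic ring with 2 hetero atoms enters. Among the compounds with values here, no measured pair shows what this exchange does, so the expectation rests only on the two values in hand, which sit close together. The expected change, a 1.6-fold higher number from compound 2 to compound 3 (0.21 log units; within the scatter), is a slight weakening that stays within the scatter, though with wide uncertainty. For compound 3 the estimated value is 1200 nM, with an expected range of 300 nM to 5000 nM.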

Compound 3, half-maximal inhibitory concentration: 99 nM
Compound 3: the middle estimate sits 12-fold (1.08 log units) above what was measured; the whole stated range lies above it.
By their numbers in this assay, from the lowest: compound 3; then compounds 2 and 1 (each within the scatter of the next).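

In this assay, within the data shown here, the group on the sulfonyl sulfur turns out to matter, with a 7.5-fold lower number from compound 2 to compound 3 (0.88 log units; beyond the scatter) when the 3,5-dimethylmorpholin-4-yl group gives way to the seven-membered non-aromatic ring with 2 hetero atoms; the earlier compounds offered no step at this position. The exchange alters several things at once: the ring size, a ring oxygen replaced by a nitrogen, one hydrogen-bond donor gained, and the 2 defined stereocentres of the leaving group gone, so the step cannot be assigned to any one of them. No measurement here bears on why the number falls.

The compounds shown leave open whether a six-membered piperazin-1-yl group would give a similar result, which would separate ring size from the exchange of oxygen for nitrogen. They also leave open what an acetyl group on the ring nitrogen of compound 3 would do.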